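A few compounds are considered here, and "the series" means these few. Any claim that something is new, unique, unknown or untested is made for them only; others in the source may bear on it.

Compound 1 `Cc1ccnc(/C(N)=N/NC(=S)N2CCSCC2)c1`: 33.8%
Compound 2 `N/C(=N\NC(=S)N1CCSCC1)c1ccccn1`: 29%
Compound 3 `N/C(=N\NC(=S)N1CCN(c2ccccn2)CC1)c1ccccn1`: 37.2%

All three were tested in a functional assay on MCF7 cells (Homo sapiens) for cytotoxicity, read by MTT assay, with a stated time of 72 h, tested at 3 uM; a higher number here means more inhibition of growth at the concentration tested, a lower number less inhibition of growth. On these numbers compound 1 stands second of three, with compound 3 giving 37.2% and compound 2 giving 29%; both gaps to compound 1 lie within the usual scatter, so the three compounds cannot be told apart here.

Going by the values given here, only one step between compounds that differ in a single place has been measured, a number 4.8 percentage points lower from compound 1 to compound 2 (within the scatter), and it concerns hydrogen in place of methyl on an aromatic carbon. Compound 4 `Cc1ccnc(/C(N)=N/NC(=S)N2CCCC2)c1` keeps that methyl and instead changes the ring attached to the thiocarbonyl carbon: pyrrolidin-1-yl in place of thiomorpholin-4-yl on a thiocarbonyl carbon. Among the compounds with values here, no measured step touches this position; compound 3 carries yet another group there but also lacks the methyl, so its number cannot be assigned to either change alone. Within the data shown here, the measured step therefore gives no direct guide, and the one comparison available shows a gap within the scatter.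

On that basis compound 4 is expected to land near compound 1, with an estimated step of a number 3.8 percentage points lower from compound 1 to compound 4 (within the scatter) in this assay. The estimate for compound 4 is 30%, expected to fall between 14% and 46%.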

Compound 4, percent growth inhibition at one concentration: 57.7%
For compound 4 the middle estimate is 27.7 percentage points below the measured one, outside the stated range (above it).
By their numbers in this assay, from the lowest: compounds 2, 1 and 3 (each within the scatter of the next); then compound 4.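

In this assay, going by these compounds alone, the ring on the thiocarbonyl carbon proves to be a place where the number can move: pyrrolidin-1-yl in place of thiomorpholin-4-yl gives a number 23.9 percentage points higher from compound 1 to compound 4 (beyond the scatter), whereas the only earlier single change, hydrogen in place of methyl on an aromatic carbon, gave a number 4.8 percentage points lower from compound 1 to compound 2 (within the scatter) and stayed within the scatter. This swap exchanges a six-membered ring with 2 hetero atoms, one of them sulfur, for a five-membered ring whose only hetero atom is nitrogen, so ring size and the loss of sulfur change together and the step cannot be assigned to either one alone. Nothing available explains why this swap raises the growth inhibition.

Still open, as far as these compounds go, is whether ring size or sulfur carries the step, a question that piperidin-1-yl, a six-membered ring with nitrogen and no sulfur, would help to settle. Also open, from the compounds shown here alone, are whether the step holds when pyrrolidin-1-yl is paired with hydrogen in place of the methyl, and whether an open-chain group such as diethylamino on the thiocarbonyl carbon would behave like the rings.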